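The source may hold more compounds than are shown below. What is called first, only, known or untested is meant among the compounds shown, and "the series" means these compounds.

Of the compounds shown here, three sharing one core have been measured in a functional assay on CHO cells for antagonist activity at prostaglandin E2 receptor EP3 subtype (Homo sapiens), read by cAMP accumulation; a lower number here means a stronger inhibitor, a higher number a weaker inhibitor. Compound 1 `CC(C)C(Cc1nnc[nH]1)c1ccc(-c2ccc3cccc(F)c3c2)[nH]c1=O` gives 17 nM. Compound 2 `Cc1nc(C(c2ccc(-c3ccc4cccc(F)c4c3)[nH]c2=O)C(C)C)[nH]c1C` gives 50 nM, and compound 3 `CC(C)C(c1cnc(N)s1)c1ccc(-c2ccc3cccc(F)c3c2)[nH]c1=O` gives 39 nM. Compound 3 thus stands second highest of the three: it sits close to compound 2, as the step of a 1.3-fold lower number from compound 2 to compound 3 (0.11 log units; within the scatter) shows, and furthest from compound 1, as the step of a 2.3-fold higher number from compound 1 to compound 3 (0.36 log units; beyond the scatter) shows.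

Compound 4 `CC(C)C(Cc1noc(=O)[nH]1)c1ccc(-c2ccc3cccc(F)c3c2)[nH]c1=O` differs from compound 3 by a group of 7 heavy atoms (3 carbon, 2 nitrogen, 2 oxygen; one five-membered aromatic ring with 3 hetero atoms) in place of a group of 6 heavy atoms (3 carbon, 2 nitrogen, 1 sulfur; one five-membered aromatic ring with 2 hetero atoms), on a saturated chain carbon bound to an aromatic carbon and a saturated chain carbon. Going by the values given here, the steps that bear on this change are a 2.9-fold higher number from compound 1 to compound 2 (0.47 log units; beyond the scatter) and a 2.3-fold higher number from compound 1 to compound 3 (0.36 log units; beyond the scatter), both modest rises when the group of compound 1 at that chain carbon was exchanged. Compound 4 returns that position to a ring carried on a chain, closer in build to compound 1 than to compound 2 or compound 3, so a modest fall in this assay is expected rather than a rise or no change. Compound 4 is therefore expected to give about 20 nM, between 8 nM and 60 nM. This estimate corresponds to an expected step of a 2.0-fold lower number from compound 3 to compound 4 (0.29 log units; within the scatter).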

Compound 4, half-maximal inhibitory concentration: 70 nM
Compound 4: the middle estimate sits 3.5-fold (0.54 log units) below what was measured; the measured number lies above the stated range.
By their numbers in this assay, from the lowest: compound 1; then compounds 3, 2 and 4 (each within the scatter of the next).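

In this assay, going by these compounds alone, a 4.1-fold higher number from compound 1 to compound 4 (0.61 log units; beyond the scatter) is the first step here that exchanges only the five-membered aromatic ring while keeping the chain that carries it, and it is beyond the scatter. A ring carried on a chain therefore does not by itself keep the number of compound 1, and the ring's own make-up counts at this position. Compound 4 does not separate from the compounds with a ring placed directly on the saturated chain carbon, as a 1.8-fold higher number from compound 3 to compound 4 (0.25 log units; within the scatter) and a 1.4-fold higher number from compound 2 to compound 4 (0.15 log units; within the scatter) both lie within the scatter, so of the four only compound 1 stands apart.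

No measurement shown accounts for the difference between the two chain-borne rings. Going by these compounds, it remains open whether a tetrazole or a carboxylic acid on the same chain, or the (4H-1,2,4-triazol-3-yl) ring on a longer chain, would stay with compound 1 or with compound 4.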